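From compound 3 to compound 4: an open step

The compounds below may be only part of what the source reports. "The series", "measured", "known", "first", "only" and "open" are said of these compounds alone.

Compound 1 `NCCCCN(C[C@H]1Cc2cccnc2CN1)[C@H]1CCCc2cccnc21` gives 69%
Compound 2 `NCCCCN(C[C@@H]1Cc2cccnc2CN1)[C@H]1CCCc2cccnc21` gives 25%
Compound 3 `NC(=O)NC/C=C/CN(C[C@H]1Cc2ncccc2CN1)[C@H]1CCCc2cccnc21` gives 19%

In an ADME assay on microsomes from liver (Mus musculus) for metabolic stability, using NADPH, with a stated time of 10 min (a lower number here means that less of the compound is left, a higher number that more of the compound is left), compound 3 gives 19% (within the scatter of compound 2 at 25% and well under compound 1 at 69%). Among the compounds with values here, the change to compound 4 `c1cnc2c(c1)CN[C@@H](CN(CCCCNC1COC1)[C@H]1CCCc3cccnc31)C2` is a group of 8 heavy atoms (6 carbon, 1 nitrogen, 1 oxygen; one four-membered non-aromatic ring with 1 hetero atom) in place of a group of 7 heavy atoms (4 carbon, 2 nitrogen, 1 oxygen; no ring), on a saturated chain carbon bound to an amine nitrogen and no measured step covers it. Within the data shown here, the sole measured step, a number 44 percentage points lower from compound 1 to compound 2 (beyond the scatter) and large, rests on the fact that compounds 1 and 2 differ only in the configuration as drawn alone, so it bears only indirectly, showing that numbers here can move far. Compound 1 at 69% shows the room upward. A moderate upward step in this assay is expected, estimated as a number 16 percentage points higher from compound 3 to compound 4 (beyond the scatter) with wide uncertainty. Compound 4 is estimated at 35% (range 12% to 65%).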

Compound 4, percent of the compound remaining: 41%
For compound 4 the middle estimate is 6 percentage points below the measured one; measured number inside the range.
By their numbers in this assay, from the lowest: compounds 3 and 2 (each within the scatter of the next); then compound 4; then compound 1.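

In this assay the read-out lies a number 22 percentage points higher from compound 3 to compound 4 (beyond the scatter) when a group with one four-membered non-aromatic ring with 1 hetero atom replaces an open group with no ring, on a saturated chain carbon bound to an amine nitrogen. This is the first step shown at this place, as the earlier pair differed only in configuration. Nothing given here accounts for this step.

On these data alone, whether the ring or the loss of the double bonds outside aromatic rings carries the step stays open. So does how a carboxylic acid or a longer chain would read at this place in this assay.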